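The compounds below may be only part of what the source reports. "The series", "measured", "known", "first", "only" and "open" are said of these compounds alone.

Measured compounds in an assay on membranes from brain for displacement of a labelled ligand from Neuronal acetylcholine receptor; alpha4/beta2 (Rattus norvegicus), with a stated time of 3 h; a lower number here means a stronger inhibitor, a higher number a weaker inhibitor:
compound 1 `CC(=O)c1ccc(/C=C2\CCCN=C2c2cccnc2)cc1`: 4490 nM
compound 2 `FC(F)Oc1ccc(/C=C2\CCCN=C2c2cccnc2)cc1`: 1160 nM
compound 3 `CC(C)(C)Oc1ccc(/C=C2\CCCN=C2c2cccnc2)cc1`: 2170 nM

Compound 3 holds the second highest of the three numbers in this assay. Its nearest neighbour is compound 2, and that gap, a 1.9-fold higher number from compound 2 to compound 3 (0.27 log units; within the scatter), lies within the scatter, so the two cannot be ordered. Against compound 1 it is set apart: a 2.1-fold lower number from compound 1 to compound 3 (0.32 log units; beyond the scatter). The change from compound 3 to compound 4 `COc1ccc(/C=C2\CCCN=C2c2cccnc2)cc1` is methyl in place of tert-butyl on an oxygen on an aromatic ring. Going by the values given here, only one measured step touches the same oxygen, that from compound 2 to compound 3, and it stayed within the scatter. The two other steps, a 3.9-fold lower number from compound 1 to compound 2 (0.59 log units; beyond the scatter) and a 2.1-fold lower number from compound 1 to compound 3 (0.32 log units; beyond the scatter), concern the exchange of acetyl for an alkoxy group and bear on the present change only in showing that both alkoxy variants sit below compound 1. Nothing measured shows that the size of the alkyl on this oxygen moves the number beyond the scatter. Compound 4 is therefore expected near compound 3 and compound 2, with a step estimated at a 1.6-fold lower number from compound 3 to compound 4 (0.19 log units; within the scatter), a slightly lower number but not beyond the scatter with confidence. The estimate for compound 4 is 1400 nM, with a range from 450 nM to 4500 nM.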

Compound 4, inhibition constant: 490 nM
For compound 4 the middle estimate is 2.9-fold (0.46 log units) above the measured one; measured number inside the range.
By their numbers in this assay, from the lowest: compound 4; then compounds 2 and 3 (each within the scatter of the next); then compound 1.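

In this assay, going by these compounds alone, the group on this oxygen does matter: a 4.4-fold lower number from compound 3 to compound 4 (0.65 log units; beyond the scatter) for methyl in place of tert-butyl, and a 2.4-fold lower number from compound 2 to compound 4 (0.37 log units; beyond the scatter) for methyl in place of difluoromethyl, whereas the only earlier step at this oxygen, a 1.9-fold higher number from compound 2 to compound 3 (0.27 log units; within the scatter), stayed within the scatter. With a 9.2-fold lower number from compound 1 to compound 4 (0.96 log units; beyond the scatter) for methoxy in place of acetyl, compound 4 now holds the lowest number of the four, and its steps to all three others lie beyond the scatter, so the oxygen substituents no longer read as interchangeable. These are differences in the numbers only, and no measurement shown accounts for them.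

Still open, from the compounds shown here alone, is whether the lower number belongs to methyl alone or extends to ethyl, isopropyl or a longer alkyl chain on the same oxygen, which would show how the number runs between methyl and tert-butyl. Also open, going by these compounds, is how a free hydroxyl, or an amine in place of the alkoxy group, would read in this assay on the same shared core.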